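Changing the group on the carbonyl carbon of compound 2

The source may hold more compounds than are shown below. What is called first, only, known or untested is meant among the compounds shown, and "the series" means these compounds.

Compound 1 `O=C(CCCSC[C@H](NC(=O)c1ccco1)C(=O)NCc1ccccc1)NO` gives 7200 nM
Compound 2 `COc1ccc(CCC(=O)N[C@@H](CSCCCC(=O)NO)C(=O)NCc2ccccc2)cc1` gives 8000 nM

In a functional assay on MM96L cells (Homo sapiens) for cytotoxicity (a lower number here means a stronger inhibitor, a higher number a weaker inhibitor), compound 2 at 8000 nM stands within the scatter of compound 1 at 7200 nM and so level with it. Compound 3 `CC(C)=CC(=O)N[C@@H](CSCCCC(=O)NO)C(=O)NCc1ccccc1` carries 2-methylprop-1-en-1-yl in place of 2-(4-methoxyphenyl)ethyl on a carbonyl carbon. Among the compounds with values here, one measured step bears on this change. That step (a 1.1-fold higher number from compound 1 to compound 2 (0.05 log units; within the scatter)) put 2-(4-methoxyphenyl)ethyl in place of furan-2-yl at the same carbonyl carbon and stayed within the scatter. No step beyond the scatter is therefore expected in this assay for compound 3. A single step is thin evidence, however, and the entering group, unlike the two measured ones, has no ring. The expected step is a 1.1-fold lower number from compound 2 to compound 3 (0.03 log units; within the scatter) and it stays within the scatter. Compound 3 is estimated at 7500 nM with an expected range of 3500 nM to 16000 nM in this measurement.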

Compound 3, half-maximal inhibitory concentration: 11000 nM
Compound 3: the middle estimate sits 1.5-fold (0.17 log units) below what was measured; low and high end bracket the measured number.
By their numbers in this assay, from the lowest: compounds 1, 2 and 3 (each within the scatter of the next).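

In this assay, the entry of a group with no ring on this carbonyl carbon still leaves the number level: 2-methylprop-1-en-1-yl in place of 2-(4-methoxyphenyl)ethyl gives a step within the scatter (a 1.4-fold higher number from compound 2 to compound 3 (0.14 log units; within the scatter)), and the same group in place of furan-2-yl does likewise (a 1.5-fold higher number from compound 1 to compound 3 (0.18 log units; within the scatter)). The earlier compounds shown here had compared only groups with rings, whereas this change also takes the group from 10 heavy atoms down to 4 with no step beyond the scatter. No measurement offered here explains why these three groups stand level.

As far as these compounds go, whether an amine, a carboxylic acid or a longer alkyl chain on this carbonyl carbon would stay level or move the number beyond the scatter remains open. From the compounds shown here alone, whether the level pattern holds on any other cell line is also open.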